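A few compounds are considered here, and "the series" means these few. Any claim that something is new, unique, unknown or untested is made for them only; others in the source may bear on it.

Compound 1 `CCCn1nc(C(=O)N[C@H]2COc3ccccc3N(C)C2=S)nc1Cc1ccccc1`: in a toxicity assay on HT-29 cells (Homo sapiens) for cytotoxicity (a higher number here means that more compound is tolerated, a lower number that less compound is tolerated), compound 1 gives > 100000 nM, a limit of the assay.
Compound 2 `CC(C)n1nc(C(=O)N[C@H]2COc3ccccc3N(C)C2=S)nc1Cc1ccccc1`: in this assay compound 2 gives > 100000 nM, again a limit.
Compound 3 `CN1C(=S)[C@@H](NC(=O)c2nc(Cc3ccccc3)n(C3COC3)n2)COc2ccccc21`: in this assay compound 3 gives > 100000 nM, also a limit.

Compound 2 thus stands at the limit, as does every value shown in the series (the limit of > 100000 nM in this assay, at which 3 of the 3 values shown sit). Compound 4 `CN1C(=S)[C@@H](NC(=O)c2nc(Cc3ccccc3)n(C3CCOCC3)n2)COc2ccccc21` differs from compound 2 as follows: oxan-4-yl in place of isopropyl on an aromatic nitrogen. The measured steps that bear on this change at the same aromatic nitrogen are a step that the two limits leave unreadable from compound 2 to compound 3, a step that the two limits leave unreadable from compound 1 to compound 2 and a step that the two limits leave unreadable from compound 1 to compound 3, none of which yields a readable size. Nothing in the series therefore points to a step beyond the scatter, and the expected step of a number no higher from compound 2 to compound 4 (the limit leaves the size open) is one of no change. Compound 4 is accordingly estimated at 100000 nM, within 50000 nM to 200000 nM, most probably reported once more as a limit.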

Compound 4, half-maximal cytotoxic concentration: > 100000 nM
Compound 4 was reported as a limit (the forecaster's own chance of this, stated with the estimate: 85%); the middle value lies on the limit itself.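

Compound 4 is reported as a limit, as are compound 1, compound 2 and compound 3, so no step among these compounds can be read: the limit of > 100000 nM in this assay, at which 4 of the 4 values shown sit.

The compounds shown leave open whether propyl, isopropyl, oxetan-3-yl and oxan-4-yl on the aromatic nitrogen differ at all.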